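Swapping Bromo for Methoxy on a Shared Core

The source may hold more compounds than are shown below. What is called first, only, known or untested is meant among the compounds shown, and "the series" means these compounds.

Measured so far:
compound 1, `COc1ccc(C(Nc2ccc([N+](=O)[O-])cc2)n2c(=O)ccc3cc(O)ccc32)cc1`: 36600 nM
compound 2, `COc1ccc(C(Nc2ccc(Br)cc2)n2c(=O)ccc3cc(O)ccc32)cc1`: 19600 nM

Both compounds were tested in a functional assay on HCT-116 cells (Homo sapiens) for inhibition, read by MTT assay; on this read-out higher numbers stand for weaker inhibition and lower numbers for stronger inhibition. Compound 1 gives 36600 nM, and compound 2 gives 19600 nM. The two share the same core and differ only in one group on the aryl amine; the step of a 1.9-fold lower number from compound 1 to compound 2 (0.27 log units; within the scatter) is within the scatter, so the two numbers cannot be told apart with confidence, and compound 2 stands beside compound 1 rather than clearly apart from it.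

Compound 3, `COc1ccc(NC(c2ccc(OC)cc2)n2c(=O)ccc3cc(O)ccc32)cc1`, has not yet been measured. It follows from compound 2 by methoxy in place of bromo on an aromatic carbon, the new group sitting para to a large group, so that the 4-bromophenyl becomes a 4-methoxyphenyl. Among the compounds with values here, no measured step covers a methoxy at this place; the only step known at this place, from nitro to bromo, stayed within the scatter. The expectation is therefore a step of a 1.2-fold higher number from compound 2 to compound 3 (0.09 log units; within the scatter), that is, no change beyond the scatter. Compound 3 is estimated at 24000 nM, with a range from 8000 nM to 70000 nM.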

Compound 3, half-maximal inhibitory concentration: 73300 nM
Beside the measured number, compound 3's estimate is 3.1-fold (0.48 log units) below it; measured number outside the range, above it.
By their numbers in this assay, from the lowest: compounds 2, 1 and 3 (each within the scatter of the next, the first and the last beyond it).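

In this assay, within the data shown here, this position now shows a step beyond the scatter for the first time: putting methoxy in place of bromo on the aromatic carbon gives a 3.7-fold higher number from compound 2 to compound 3 (0.57 log units; beyond the scatter), a modest move toward weaker inhibition, so the group at this place can change the read-out. Putting methoxy in place of nitro gives a 2.0-fold higher number from compound 1 to compound 3 (0.30 log units; within the scatter), which stays within the scatter, so compound 1 cannot be separated from compound 3 or compound 2, and only the bromo and methoxy compounds stand clearly apart. The data at hand offer no measurement that accounts for this difference between bromo and methoxy.

Among these compounds, with only three groups compared at this one position, it remains open how far the read-out would move with a different group here, such as chloro, an amine or a carboxylic acid. On these data alone, it is also open whether methoxy in place of bromo would give a similar step on a different core or in a different cell line.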